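Sulfonate ester series: acyl to urea on the anilide

The compounds below may be only part of what the source reports. "The series", "measured", "known", "first", "only" and "open" are said of these compounds alone.

Measured so far:
compound 1, `CCCCCC(=O)Nc1ccc(S(=O)(=O)Oc2ccccc2C(C)C)cc1` — 6400 nM
compound 2, `CC(C)c1ccccc1OS(=O)(=O)c1ccc(NC(=O)CCl)cc1` — 5600 nM

Compound 2 carries the lowest of the two numbers recorded in a functional assay on HT-29 cells (Homo sapiens) for antiproliferative activity, read by sulforhodamine B assay, with a stated time of 48 h; a higher number here means a weaker inhibitor, a lower number a stronger inhibitor; its nearest neighbour is compound 1, and the step from compound 1 to compound 2 is a 1.1-fold lower number from compound 1 to compound 2 (0.06 log units; within the scatter), so on this assay the two compounds are not distinguished.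

Compound 3, `CCCNC(=O)Nc1ccc(S(=O)(=O)Oc2ccccc2C(C)C)cc1`, is not yet measured. Against compound 2 the change is propylamino in place of chloromethyl on a carbonyl carbon, turning the chloromethyl carbonyl into a propylcarbamoyl group. Going by the values given here, only the step from compound 1 to compound 2 bears on this position, and it was within the scatter; it covers an acyl-chain swap, not an amine on the carbonyl, so it gives no direction for compound 3. With no step beyond the scatter shown at this position, compound 3 is expected to land near compound 2, an estimated change of a 1.1-fold higher number from compound 2 to compound 3 (0.03 log units; within the scatter).

For compound 3 the expected value in this assay is 6000 nM, with a range from 2500 nM to 15000 nM.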

Compound 3, half-maximal inhibitory concentration: 6300 nM
Beside the measured number, compound 3's estimate is 1.1-fold (0.02 log units) below it, within the range that was stated.
By their numbers in this assay, from the lowest: compounds 2, 3 and 1 (each within the scatter of the next).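

Going by these compounds alone, the propylamino group is the first at this position to place a nitrogen, and with it a hydrogen-bond donor, on the carbonyl carbon. In this assay, this change does not separate the urea compound 3 from either acyl compound, whether set against chloromethyl (a 1.1-fold higher number from compound 2 to compound 3 (0.05 log units; within the scatter)) or against pentyl (a 1.0-fold lower number from compound 1 to compound 3 (0.01 log units; within the scatter)). All three compounds therefore lie within the scatter of one another, and no supporting data bear on this result.

From the compounds shown here alone, it remains open whether a longer chain or a phenyl ring on the urea nitrogen would move the number beyond the scatter. Also open is whether a carboxylic acid or a terminal amine on that chain would do so, since the compounds shown carry only simple chains at this position.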